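From fluorine to chlorine on the benzyl ring

The source may report more compounds than this note shows. Statements on the series, on what has been measured and on what is new or still open speak of the compounds shown alone.

Compound 2 `Nc1nnc(-c2ccccc2OCc2ccc(F)cc2)o1` has the lower of the two numbers in a functional assay on the whole organism with Mus musculus as the target, in the maximal electroshock model; on this read-out higher numbers stand for an effect only at larger amounts of compound and lower numbers for an effect already at smaller amounts: compound 2 gives 3.3 mg/kg, while compound 1 `Nc1nnc(-c2ccccc2OCc2ccccc2)o1` gives 63.2 mg/kg. Among the compounds with values here, the only measured step, a 19-fold lower number from compound 1 to compound 2 (1.28 log units; beyond the scatter), shows that a substituent on this ring carbon can matter a great deal. Compound 3 `Nc1nnc(-c2ccccc2OCc2ccc(Cl)cc2)o1` carries chloro in place of fluoro on an aromatic carbon. Within the data shown here, no measured step swaps one halogen for another, so there is nothing to show a direction. The step of a 1.1-fold higher number from compound 2 to compound 3 (0.03 log units; within the scatter) is therefore expected to stay within the scatter. Compound 3 is estimated at 3.5 mg/kg, in a range from 1.2 mg/kg to 10 mg/kg.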

Compound 3, dose for half-maximal effect: > 100 mg/kg
Compound 3 ended at the assay's limit; the forecaster's own chance of this, stated with the estimate: 5%; middle value at least 28-fold (1.45 log units) from the limit.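

Exchanging one halogen for the other on this ring carbon is far from a minor edit: the result is an at least 30-fold higher number from compound 2 to compound 3 (1.48 log units; beyond the scatter). The number for compound 3 is a limit of this assay, not a measured value: the limit of > 100 mg/kg in this assay, at which 1 of the 3 values shown sits.

Set against the benzyl ring without a halogen, the chloro change gives an at least 1.5-fold higher number from compound 1 to compound 3 (0.19 log units; that floor lies within the scatter), and that is only a floor, so among the compounds shown, the low number goes with fluoro and not with halogens in general. Still open, on these data alone, is how a methyl, a methoxy or a nitrile on this ring carbon would behave. Also open is why fluoro and chloro part so sharply here.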